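An Aryl Swap Where Earlier Changes Left Potency Unmoved

This account rests on a few compounds, and the source may have more. Where it says the series, first, only, none or still open, it means among the compounds named here.

Compound 2 `COc1ccc(CNC(=O)c2cc(-c3cncc(C)c3)ncc2N2CCC2)nc1OC` is measured in an assay on CHO cells for antagonist activity at Orexin/Hypocretin receptor type 1 variant I408V (Homo sapiens), read by FLIPR, with a stated time of 5 min (on this read-out lower numbers stand for stronger inhibition and higher numbers for weaker inhibition), at 10000 nM, and its neighbour compound 1 `COc1ccc(CNC(=O)c2cc(-c3cncc(C)c3)ncc2-c2cncc(F)c2)nc1OC` gives 10000 nM in this assay; the step of no change at the digits printed from compound 1 to compound 2 (within the scatter) shows no change within the scatter, so compound 2 stands level with compound 1. Compound 3 `COc1ccc(CNC(=O)c2cc(-c3cncc(C)c3)ncc2-c2ccccc2F)nc1OC` differs from compound 2 by 2-fluorophenyl in place of azetidin-1-yl on an aromatic carbon, on an aromatic carbon ortho to a large group. Among the measured compounds shown here, the only step bearing on this position, no change at the digits printed from compound 1 to compound 2 (within the scatter), was flat, and compound 1 already carries an aromatic ring there. Compound 3 is therefore expected to show no step beyond the scatter, no change at the digits printed from compound 2 to compound 3 (within the scatter), in this assay. The estimate for compound 3 is 10000 nM, with a range from 4000 nM to 10000 nM.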

Compound 3, half-maximal inhibitory concentration: 3000 nM
The estimate for compound 3 lay 3.3-fold (0.52 log units) above the measured number, and the stated range ends above it.
By their numbers in this assay, from the lowest: compound 3; then compounds 1 and 2 (each within the scatter of the next).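

The 2-fluorophenyl group brings a 3.3-fold lower number from compound 2 to compound 3 (0.52 log units; beyond the scatter) in this assay, and also a 3.3-fold lower number from compound 1 to compound 3 (0.52 log units; beyond the scatter). This position can therefore move the number after all, and an aromatic ring alone does not settle it: the 5-fluoropyridin-3-yl group stayed level with azetidin-1-yl, while a carbon-only ring bearing fluorine did not. Nothing measured here explains the step.

On these data alone, whether the ring without nitrogen or the placing of the fluorine carries the step stays open. So does whether plain phenyl or 2-chlorophenyl would lower the number further.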